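The compounds below may be only part of what the source reports. "The series", "measured", "known", "first", "only" and "open" are said of these compounds alone.

Measured compounds in an ADME assay on Huh-7 cells (Homo sapiens) for cytotoxicity, read by a luciferase reporter and WST assay, with a stated time of 3 days; a higher number here means that more compound is tolerated, a lower number that less compound is tolerated:
- compound 1, `O=C(Nc1ccccc1)c1c(NO)cc(-c2ccccc2)oc1=O`: 11600 nM
- compound 2, `O=C(Nc1ccccc1)c1c(NO)cc(-c2ccc(F)cc2)oc1=O`: 10300 nM
- compound 3, `Cc1ccc(NC(=O)c2c(NO)cc(-c3ccc(F)cc3)oc2=O)cc1`: > 20000 nM

For compound 3 this assay reports only a limit, so its standing is known only as a floor. Compound 3 sits at the limit of > 20000 nM in this assay, at which 1 of the 3 values shown sits. The step of a 1.1-fold lower number from compound 1 to compound 2 (0.05 log units; within the scatter) lies within the scatter. The step of an at least 1.9-fold higher number from compound 2 to compound 3 (0.28 log units; that floor lies within the scatter) reaches only to the limit, and its floor lies within the scatter.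

Compound 4, `COc1ccc(-c2cc(NO)c(C(=O)Nc3ccc(C)cc3)c(=O)o2)cc1`, is not yet measured. It differs from compound 3 by methoxy in place of fluoro on an aromatic carbon. Neither measured step involves this change; the two changes measured so far, fluoro in place of hydrogen and methyl in place of hydrogen, both moved the number little or only to the limit. From these the step to compound 4 in this assay is expected to stay within the scatter, with no clear direction, and compound 3 already standing at the limit. The expected step is a number no higher from compound 3 to compound 4 (the limit leaves the size open). Compound 4 is therefore estimated at 20000 nM, between 9000 nM and 45000 nM, with a fair chance that only a limit is reported again.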

Compound 4, half-maximal cytotoxic concentration: > 20000 nM
Compound 4 gave a limit, no number (the forecaster's own chance of this, stated with the estimate: 55%); the middle value sits exactly at the limit.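

Compound 3 and compound 4 each give only a limit in this assay, so the step between them cannot be read: the limit of > 20000 nM in this assay, at which 2 of the 4 values shown sit.

The compounds shown leave open whether methoxy in place of fluoro changes the tolerated concentration, and in which direction.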